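The source may hold more compounds than are shown below. What is called first, only, known or untested is meant among the compounds shown, and "the series" means these compounds.

Compound 1 `COc1cccc(/C=C2\CCCN=C2c2cccnc2)c1`: 1180 nM
Compound 2 `CCN(CC)c1ccc(/C=C2\CCCN=C2c2cccnc2)c(O)c1`: 130 nM

Both were tested in an assay on membranes from brain for displacement of a labelled ligand from Neuronal acetylcholine receptor; alpha4/beta2 (Rattus norvegicus), with a stated time of 3 h; a higher number here means a weaker inhibitor, a lower number a stronger inhibitor. Of the two numbers, compound 1 has the higher one, and compound 2 sits well below it, a gap beyond the usual scatter. Compound 3 `Oc1cccc(/C=C2\CCCN=C2c2cccnc2)c1` has not been measured yet. It differs from compound 1 by one change: hydrogen in place of methyl on an oxygen on an aromatic ring. For the measured compounds named here, no measured pair shares this change, so the expectation rests on compound 1 and the nature of the change alone. For compound 3, a modest step toward stronger binding is expected, a 2.1-fold lower number from compound 1 to compound 3 (0.33 log units; beyond the scatter), still within reach of the scatter. Compound 3 is therefore estimated at 550 nM, with a likely range from 150 nM to 2000 nM.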

Compound 3, inhibition constant: 1170 nM
For compound 3 the middle estimate is 2.1-fold (0.33 log units) below the measured one, within the range that was stated.
By their numbers in this assay, from the lowest: compound 2; then compounds 3 and 1 (each within the scatter of the next).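

Changing methoxy to hydroxy on the aromatic ring gives a 1.0-fold lower number from compound 1 to compound 3 (0.00 log units; within the scatter), so in this setting the methyl on the oxygen can be removed with no visible change in binding. For the compounds shown here, this is the first direct reading of that change, and it rests on a single pair. Nothing available explains why the two groups read alike.

Still open, as far as these compounds go, is how a longer chain on this oxygen, or an amine in place of the hydroxy, would read. Also open, from the compounds shown here alone, is whether the same change would read alike on another compound.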